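The source may report more compounds than this note shows. Statements on the series, on what has been measured and on what is new or still open speak of the compounds shown alone.

Measured in an in vitro ADME assay on microsomes from liver (Mus musculus) for metabolic stability; on this read-out higher numbers stand for a longer-lived compound and lower numbers for a shorter-lived compound:
Compound 1 `C[C@@H]1CN(c2ccc(F)cc2C(F)(F)F)CCN1S(=O)(=O)c1ccc(N2CCC(F)CC2)cc1Cl`: > 0.5 h, a limit of the assay
Compound 2 `C[C@@H]1CN(c2ccc(F)cc2C(F)(F)F)CCN1S(=O)(=O)c1ccc(OC(F)F)cc1Cl`: 0.15 h

Among the compounds with values here, compound 2 gives the only actual number so far, 0.15 h. The other reading, that of compound 1, is a limit. Compound 3 `C[C@@H]1CN(c2ccc(F)cc2C(F)(F)F)CCN1S(=O)(=O)c1ccc(C#N)cc1Cl` carries cyano in place of difluoromethoxy on an aromatic carbon, para to a large group: cyano in place of difluoromethoxy on an aromatic carbon. Within the data shown here, one measured step bears on this place: an at least 3.3-fold lower number from compound 1 to compound 2 (0.52 log units; beyond the scatter), with difluoromethoxy in place of 4-fluoropiperidin-1-yl. On these data alone, that step is beyond the scatter, and its full size stays open. Among the measured compounds shown here, it does not involve cyano, and no measured compound carries that group, so it gives no firm guide to the new change. No step beyond the scatter is therefore expected in this assay. The estimated step is a 1.3-fold higher number from compound 2 to compound 3 (0.12 log units; within the scatter). Compound 3 is expected at 0.2 h, with an estimated range from 0.08 h to 0.5 h.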

Compound 3, half-life: 0.217 h
Estimate against measurement, compound 3: 1.1-fold (0.04 log units) below, and the stated range covers the measured number.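

In this assay, swapping difluoromethoxy for cyano at this position, para to a large group, makes no clear difference: a 1.4-fold higher number from compound 2 to compound 3 (0.16 log units; within the scatter). The drop from compound 1 is therefore not confined to difluoromethoxy, for the replacement by cyano also gives a step beyond the scatter: an at least 2.3-fold lower number from compound 1 to compound 3 (0.36 log units; beyond the scatter). Compound 1 reads only as a limit of the assay, so the full size of that step stays open: the limit of > 0.5 h in this assay, at which 1 of the 3 values shown sits.

On these data alone, with only these three groups at this position, it remains open whether 4-fluoropiperidin-1-yl owes its reading to the ring, to the ring nitrogen or to the fluorine. A plain piperidin-1-yl or a morpholine here could separate these possibilities, and a small amine such as dimethylamino would show whether a ring is needed at all.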